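A few compounds are considered here, and "the series" means these few. Any claim that something is new, unique, unknown or untested is made for them only; others in the source may bear on it.

Measured in an ADME assay on HEK293 cells (Homo sapiens) for cytotoxicity, read by MTT assay, with a stated time of 48 h; a lower number here means a stronger inhibitor, a higher number a weaker inhibitor:
compound 1 `CCN(CC)CCn1c(N)c(-c2nc3ccccc3[nH]2)c2nc(C#N)c(C#N)nc21`: 12200 nM
compound 2 `CCN(CC)CCCCn1c(N)c(-c2nc3ccccc3[nH]2)c2nc(C#N)c(C#N)nc21`: 5370 nM
compound 3 `CCN(CC)CCn1c(N)c(-c2nc3cc(Cl)ccc3[nH]2)c2nc(C#N)c(C#N)nc21`: > 50000 nM

Compound 3 has no exact number, only the limit of the assay at > 50000 nM. Compound 4 `CCN(CC)CCCCn1c(N)c(-c2nc3cc(Cl)ccc3[nH]2)c2nc(C#N)c(C#N)nc21` differs from compound 3 only in its chain: 2-(diethylamino)ethyl in place of diethylamino on a saturated chain carbon, two bonds along the chain from an aromatic nitrogen. The same change, made without the chloro, gave a 2.3-fold lower number from compound 1 to compound 2 (0.36 log units; beyond the scatter), a modest step beyond the scatter. Adding the chloro gave an at least 4.0-fold higher number from compound 1 to compound 3 (0.61 log units; beyond the scatter), which shows why compound 3 has so far to fall. As far as these compounds go, how far compound 3 lies past its limit is unknown, but a modest fall in this assay is expected. The expected step is an at least 1.7-fold lower number from compound 3 to compound 4 (0.25 log units; that floor lies within the scatter). For compound 4 the estimated value is 28000 nM, with an expected range of 14000 nM to 55000 nM.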

Compound 4, half-maximal inhibitory concentration: 3860 nM
Compound 4: middle estimate off by 7.3-fold (0.86 log units), on the high side; measured number below the stated range.
By their numbers in this assay, from the lowest: compounds 4 and 2 (each within the scatter of the next); then compound 1. At a limit, above all of these: compound 3.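

In this assay, the longer chain counts for far more on the chloro core than on the core without chloro, with an at least 12-fold lower number from compound 3 to compound 4 (1.11 log units; beyond the scatter), so the size of this change depends on the core: the same change on two cores in this assay, a 2.3-fold lower number (0.36 log units; beyond the scatter) from compound 1 to compound 2 and an at least 12-fold lower number (1.11 log units; beyond the scatter) from compound 3 to compound 4, at least 5.7-fold (0.75 log units) apart, beyond the scatter of two such steps Compound 3 sits at a limit of the assay, > 50000 nM, so this step is only a floor. The chloro also matters only on the shorter chain, since on the longer chain there is a 1.4-fold lower number from compound 2 to compound 4 (0.14 log units; within the scatter): the same change on two cores in this assay, an at least 4.0-fold higher number (0.61 log units; beyond the scatter) from compound 1 to compound 3 and a 1.4-fold lower number (0.14 log units; within the scatter) from compound 2 to compound 4, at least 5.7-fold (0.75 log units) apart, beyond the scatter of two such steps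

As far as these compounds go, whether a 3-(diethylamino)propyl chain, a pyrrolidine in place of the diethylamino group, or a fluoro in place of the chloro would behave the same way remains open.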